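From Benzyl to 4-Aminophenyl on a Shared Core

The source may hold more compounds than are shown below. What is called first, only, known or untested is meant among the compounds shown, and "the series" means these compounds.

Three compounds have been run in a functional assay on HCT-116 cells (Homo sapiens) for cytotoxicity, read by MTT assay, with a stated time of 72 h; on this read-out higher numbers stand for weaker inhibition and lower numbers for stronger inhibition. Compound 1 `N[C@H]1CC[C@H](Nc2c(C(=O)NCc3ccc(F)cc3)nc(N3CCCCC3)c3cccnc23)CC1` gives 8500 nM. For compound 2 `O=C(NCc1ccc(F)cc1)c1nc(Br)c2cccnc2c1NCCCNc1c(C(=O)NCc2ccc(F)cc2)nc(Br)c2cccnc12` the assay returns only its limit, > 20000 nM. Compound 3 `O=C(NCc1ccc(F)cc1)c1nc(Br)c2cccnc2c1NCc1ccccc1` likewise stands at the limit, > 20000 nM, and no number is known for it. Two of the three values shown sit at that limit (the limit of > 20000 nM in this assay, at which 2 of the 3 values shown sit). Compound 4 `Nc1ccc(Nc2c(C(=O)NCc3ccc(F)cc3)nc(Br)c3cccnc23)cc1` differs from compound 3 by 4-aminophenyl in place of benzyl on a nitrogen on an aromatic ring. Among the measured compounds shown here, no step between measured compounds calibrates this change, and compound 1 is the only compound with a number. Compound 4 is therefore expected near 15000 nM, within 5000 nM to 40000 nM. The expected step from compound 3 to compound 4 is an at least 1.3-fold lower number from compound 3 to compound 4 (0.12 log units; that floor lies within the scatter), with a real chance that only a limit is again reported.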

Compound 4, half-maximal inhibitory concentration: 7000 nM
Beside the measured number, compound 4's estimate is 2.1-fold (0.33 log units) above it, within the range that was stated.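

In this assay, among the compounds shown here, 4-aminophenyl in place of benzyl on a nitrogen on an aromatic ring brings an at least 2.8-fold lower number from compound 3 to compound 4 (0.45 log units; beyond the scatter), the first step that can be read at this position. The change therefore moves the read-out off the limit, with the same count of heavy atoms in the group that leaves and the group that enters. The step is only a floor because compound 3 stands at a limit: the limit of > 20000 nM in this assay, at which 2 of the 4 values shown sit.

From the compounds shown here alone, it remains open whether the step comes from the amine on the ring or from the loss of the benzyl link. A plain phenyl on the same nitrogen would separate the two.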